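A few compounds are considered here, and "the series" means these few. Any claim that something is new, unique, unknown or untested is made for them only; others in the source may bear on it.

Compound 1, `Cc1ncc([N+](=O)[O-])n1CCSC(=S)N1CCC(Cc2ccccc2)CC1`. In an ADME assay on HeLa cells (Homo sapiens) for cytotoxicity (on this read-out lower numbers stand for stronger inhibition and higher numbers for weaker inhibition), compound 1 reaches only the limit of the assay, > 1000 ug/mL.
Compound 2, `Cc1ncc([N+](=O)[O-])n1CCSC(=S)N1CCC(OC(=O)CN2CCCCC2)CC1`. Compound 2 gives 760 ug/mL.
Compound 3, `Cc1ncc([N+](=O)[O-])n1CCSC(=S)N1CCC(=O)CC1`. Compound 3 also reaches only a limit, > 1000 ug/mL.

Compound 1 therefore stands at a limit rather than a number, (the limit of > 1000 ug/mL in this assay, at which 2 of the 3 values shown sit). Compound 4, `Cc1ncc([N+](=O)[O-])n1CCSC(=S)N1CCC(O)CC1`, has not yet been measured; it differs from compound 1 by hydroxy in place of benzyl on a saturated ring carbon. Going by the values given here, the one measured step that starts from compound 1 is an at least 1.3-fold lower number from compound 1 to compound 2 (0.11 log units; that floor lies within the scatter), a change at the same saturated ring carbon whose floor lies within the scatter; no measured step involves a hydroxy group. The expected step is accordingly a step that the limit leaves unreadable from compound 1 to compound 4, none beyond the scatter. Compound 4 is estimated at 1200 ug/mL, in the range 600 ug/mL to 2500 ug/mL, most probably reported again only as a limit.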

Compound 4, half-maximal inhibitory concentration: 930 ug/mL
Compound 4: the middle estimate sits 1.3-fold (0.11 log units) above what was measured; measured number inside the range.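

Hydroxy in place of benzyl on this saturated ring carbon gives an at least 1.0-fold lower number from compound 1 to compound 4 (0.03 log units; that floor lies within the scatter), and 4-hydroxypiperidin-1-yl in place of 4-oxopiperidin-1-yl gives an at least 1.0-fold lower number from compound 3 to compound 4 (0.03 log units; that floor lies within the scatter). Taking ((piperidin-1-yl)methyl)carbonyl off the oxygen gives a 1.2-fold higher number from compound 2 to compound 4 (0.09 log units; within the scatter), so none of the changes at this position yet shows a step beyond the scatter. Two of the comparisons rest on a limit rather than a number: the limit of > 1000 ug/mL in this assay, at which 2 of the 4 values shown sit.

Going by these compounds, it stays open whether an amine or a carboxylic acid on this saturated ring carbon would shift the value in this assay beyond the scatter.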